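Fluorophenyl Replaces Chlorophenyl on the Ring Nitrogen

The source may report more compounds than this note shows. Statements on the series, on what has been measured and on what is new or still open speak of the compounds shown alone.

compound 1 `CCCn1c(=O)[nH]c2nc(-c3ccc(S(=O)(=O)N4CCN(C)CC4)cc3)[nH]c2c1=O`: 7%
compound 2 `CCCn1c(=O)[nH]c2nc(-c3ccc(S(=O)(=O)N4CCN(Cc5ccc(Br)cc5)CC4)cc3)[nH]c2c1=O`: 28%
compound 3 `CCCn1c(=O)[nH]c2nc(-c3ccc(S(=O)(=O)N4CCN(c5ccccc5Cl)CC4)cc3)[nH]c2c1=O`: 32%

In an assay on CHO cells for displacement of a labelled ligand from adenosine receptor A3 (Homo sapiens), read by scintillation counting, with a stated time of 45 min, tested at 1 uM, in the presence of a further agent that is not named here (on this read-out higher numbers stand for more inhibition at the one concentration tested (going by the name of the read-out) and lower numbers for less inhibition), compound 3 stands highest of the three numbers, with compound 2 close behind a number 4 percentage points higher from compound 2 to compound 3 (within the scatter) and compound 1 well below a number 25 percentage points higher from compound 1 to compound 3 (beyond the scatter). Compound 4 `CCCn1c(=O)[nH]c2nc(-c3ccc(S(=O)(=O)N4CCN(c5ccc(F)cc5)CC4)cc3)[nH]c2c1=O` differs from compound 3 in one place: 4-fluorophenyl in place of 2-chlorophenyl on an amine nitrogen in a ring. Going by the values given here, the steps that bear on this change are the two arriving at compound 3, the modest a number 25 percentage points higher from compound 1 to compound 3 (beyond the scatter) and a number 4 percentage points higher from compound 2 to compound 3 (within the scatter), together with a number 21 percentage points higher from compound 1 to compound 2 (beyond the scatter); an aryl or benzyl group on the ring nitrogen in each case carried the number upward from compound 1, while exchanging one such group for another moved it little. Compound 4 is therefore expected to stay near compound 3, with a step of a number 5 percentage points lower from compound 3 to compound 4 (within the scatter), and is estimated at 27% within 12% to 42%.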

Compound 4, a percentage reported as inhibition, at one concentration (the size of the read-out at that concentration, not a potency): 38%
Compound 4: the middle estimate sits 11 percentage points below what was measured, within the range that was stated.
By their numbers in this assay, from the lowest: compound 1; then compounds 2, 3 and 4 (each within the scatter of the next).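

In this assay, the swap on the ring nitrogen gives a number 6 percentage points higher from compound 3 to compound 4 (within the scatter), and replacing 4-bromobenzyl gives a number 10 percentage points higher from compound 2 to compound 4 (within the scatter), so a third halogen-bearing aromatic group joins the other two at a similar level. Only replacing methyl gives a step beyond the scatter, a number 31 percentage points higher from compound 1 to compound 4 (beyond the scatter). Nothing measured here accounts for these numbers. On these data alone, the halogen and its place on the ring change together in this swap, so neither can be judged alone, and it remains open whether an unsubstituted phenyl or a cyclohexyl group on this nitrogen would reach the same level.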